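Replacing pyrrolidin-1-yl with hydroxymethyl in compound 3

The compounds below may be only part of what the source reports. "The series", "measured", "known", "first", "only" and "open" are said of these compounds alone.

In a physicochemical assay for lipophilicity, at pH 7.4 (on this read-out lower numbers stand for lower lipophilicity and higher numbers for higher lipophilicity), compound 3 `C[C@H]1C(=O)N(C)C=Cc2cc(CN3CCCC3)ccc21` gives 1.5 and stands lowest of the three measured compounds, under compound 2 `COCCOc1ccc2c(c1)C=CN(C)C(=O)[C@@H]2C` at 4 and compound 1 `C[C@H]1C(=O)N(C)C=Cc2ccccc21` at 4.3 on the shared core. Compound 4 `C[C@H]1C(=O)N(C)C=Cc2cc(CCO)ccc21` is still unmeasured and differs from compound 3 thus: hydroxymethyl in place of pyrrolidin-1-yl on a saturated chain carbon bound to an aromatic carbon. The steps of a number 2.80 log units lower from compound 1 to compound 3 (beyond the scatter) and a number 2.50 log units lower from compound 2 to compound 3 (beyond the scatter) both bring in (pyrrolidin-1-yl)methyl, whereas 2-methoxyethoxy gives only a number 0.30 log units lower from compound 1 to compound 2 (within the scatter) as its step. A large upward move is therefore expected, estimated as a number 2.10 log units higher from compound 3 to compound 4 (beyond the scatter) in this case. Compound 4 is expected at 3.6 with 3 to 4.1 as its range.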

Compound 4, distribution coefficient: 2.6
The estimate for compound 4 lay 1.00 log units above the measured number; the whole stated range lies above it.
By their numbers in this assay, from the lowest: compound 3; then compound 4; then compounds 2 and 1 (each within the scatter of the next).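

In this assay the exchange on this saturated chain carbon gives a number 1.10 log units higher from compound 3 to compound 4 (beyond the scatter) and so recovers only part of the drop seen with (pyrrolidin-1-yl)methyl on the shared core. Unlike 2-methoxyethoxy, 2-hydroxyethyl is itself a large step down, with a number 1.70 log units lower from compound 1 to compound 4 (beyond the scatter) and a number 1.40 log units lower from compound 2 to compound 4 (beyond the scatter) as its steps. Nothing measured here explains the sizes of these steps.

Going by these compounds, what stays open is whether an open-chain amine such as diethylamino on the same carbon would stand nearer compound 3 or compound 4. Where a carboxylic acid would fall at this place is also open.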